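Swapping Isopropyl for Trifluoromethyl on an Aromatic Carbon

This account rests on a few compounds, and the source may have more. Where it says the series, first, only, none or still open, it means among the compounds named here.

Measured compounds:
compound 1 `O=C(N/N=C/c1ccc(-c2ccccc2)cc1)c1cnccn1`: 47.7%
compound 2 `O=C(N/N=C/c1ccccc1)c1cnccn1`: 30.5%
compound 3 `CC(C)c1ccc(/C=N/NC(=O)c2cnccn2)cc1`: 46.6%

Of the compounds shown here, three sharing one core have been tested in a functional assay on the whole organism (strain Swiss) for inhibition, with Mus musculus as the target, read by paw edema, with stated times of 40 min and 30 min, at a dose of 100 umol/kg by the oral route; a lower number here means less inhibition, a higher number more inhibition at the dose given (going by the name of the read-out). Compound 3 stands second highest of the three; its nearest neighbour is compound 1, and the gap between them lies within the scatter (a number 1.1 percentage points lower from compound 1 to compound 3 (within the scatter)), so the two cannot be ranked. The clear divide is with compound 2, where the step from hydrogen to isopropyl on an aromatic carbon is modest but beyond the scatter (a number 16.1 percentage points higher from compound 2 to compound 3 (beyond the scatter)), and likewise the step from compound 1 to compound 2 (a number 17.2 percentage points lower from compound 1 to compound 2 (beyond the scatter)).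

Compound 4 `O=C(N/N=C/c1ccc(C(F)(F)F)cc1)c1cnccn1` has not yet been measured. It differs from compound 3 in one place: trifluoromethyl in place of isopropyl on an aromatic carbon. The relevant steps are those at this same position. Removing the group altogether lowered the number modestly, while exchanging one sizeable group for another (isopropyl against phenyl) left the number within the scatter. Trifluoromethyl keeps a group of comparable heavy-atom count at this position, so the expected step in this assay, a number 3.6 percentage points lower from compound 3 to compound 4 (within the scatter), is small and could fall either way within the scatter. Compound 4 is therefore estimated at 43%, with a range from 30% to 55%.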

Compound 4, a percentage reported as inhibition, in the whole organism at one dose (the size of the read-out at that dose, not a potency): 48.3%
Compound 4: middle estimate off by 5.3 percentage points, on the low side; the measured number falls inside the stated range.
By their numbers in this assay, from the lowest: compound 2; then compounds 3, 1 and 4 (each within the scatter of the next).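

In this assay, trifluoromethyl is a third group tested on this aromatic carbon, para to a large group, and a number 1.7 percentage points higher from compound 3 to compound 4 (within the scatter) and a number 0.6 percentage points higher from compound 1 to compound 4 (within the scatter) show that it cannot be ranked against isopropyl or phenyl, although the three groups differ in their atoms and only phenyl has a ring. Only hydrogen stands apart, with a number 17.8 percentage points higher from compound 2 to compound 4 (beyond the scatter), a modest step in the same direction as a number 16.1 percentage points higher from compound 2 to compound 3 (beyond the scatter), so among these four compounds, each of the three groups goes with more inhibition at this dose than hydrogen does, and none of the compounds goes against this. Nothing measured here explains why such different groups give numbers that cannot be told apart.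

On these data alone, whether an amine or a carboxylic acid in this place would keep the number level with these three groups remains open, as does whether a single methyl group or chlorine atom would already be enough to separate it from hydrogen. The read-out also comes from a single dose, so how the potencies of these compounds compare remains unknown.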